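Compound 2 to compound 4: replacing 4-methoxyphenyl

This account rests on a few compounds, and the source may have more. Where it says the series, first, only, none or still open, it means among the compounds named here.

Values in a functional assay on MCF7 cells (Homo sapiens) for antiproliferative activity, read by MTT assay, with a stated time of 72 h (a higher number here means a weaker inhibitor, a lower number a stronger inhibitor), follow
- compound 1 `COc1cc(-c2ncnn2-c2cccc(N)c2)cc(OC)c1OC` gives > 10000 nM (a limit)
- compound 2 `COc1ccc(-c2ncnn2-c2cc(OC)c(OC)c(OC)c2)cc1` gives 360 nM
- compound 3 `COc1cc(-n2ncnc2-c2ccc(OC(C)C)cc2)cc(OC)c1OC` gives 610 nM
- compound 4 `COc1cc(-n2ncnc2-c2cccc(Cl)c2)cc(OC)c1OC` is not yet measured

Within the data shown here, compound 2 holds one of only two numbers in this assay and its nearest neighbour lies close (a 1.7-fold higher number from compound 2 to compound 3 (0.23 log units; within the scatter)) so the two cannot be ranked. The value of compound 1 is a limit and offers no number for comparison.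

The change under study is 3-chlorophenyl in place of 4-methoxyphenyl on an aromatic carbon with the rest of the structure kept. Among the measured compounds shown here, the one measured step that bears on it (a 1.7-fold higher number from compound 2 to compound 3 (0.23 log units; within the scatter)) alters only the group on oxygen and leaves that oxygen in place. For the measured compounds named here, no measured step removes it. Compound 2 (360 nM) and compound 3 (610 nM) both keep that oxygen, so a move to a higher number in this assay is expected, with wide uncertainty. The expected size is a 5.6-fold higher number from compound 2 to compound 4 (0.74 log units; beyond the scatter) and this remains an estimate. For compound 4 the estimated value (2000 nM) carries an expected range (300 nM to 10000 nM).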

Compound 4, half-maximal inhibitory concentration: > 10000 nM
Compound 4: only a limit was reported (the forecaster's own chance of this, stated with the estimate: 25%); at least 5.0-fold (0.69 log units) between middle value and limit.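

Until now, this position had only been probed by changing the group on the oxygen, with that oxygen kept. In this assay, exchanging the whole aryl group on this aromatic carbon gives a clear loss, an at least 27-fold higher number from compound 2 to compound 4 (1.44 log units; beyond the scatter), so the position is not indifferent to the group it carries, at least in this one exchange. The value of compound 4 is a limit and not a number, so the step gives only a bound on the loss, and that limit is shared: the limit of > 10000 nM in this assay, at which 2 of the 4 values shown sit.

The exchange removes the methoxy group and brings in chlorine together, so the two changes cannot be told apart here. A plain phenyl, or a phenyl carrying an ethoxy group or a carboxylic acid, at this position would show how much of the oxygen-bearing substituent is needed.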